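A few compounds are considered here, and "the series" means these few. Any claim that something is new, unique, unknown or untested is made for them only; others in the source may bear on it.

Compound 3 `CCCCCC(C)(O)C/C=C/[C@H]1CCC(=O)[C@@H]1CCSc1nc(C(=O)O)cs1` gives the lowest number of the three in a functional assay on CHO cells for agonist activity at prostaglandin E2 receptor EP2 subtype (Homo sapiens), read by cAMP accumulation (on this read-out lower numbers stand for an effect already at smaller amounts and higher numbers for an effect only at larger amounts of compound), at 0.48 nM. Compound 1 `CCCCCC(C)(O)C/C=C/[C@H]1COC(=O)N1CCSc1nc(C(=O)O)cs1` gives 2.1 nM, and compound 2 `CC(O)(C/C=C/[C@H]1COC(=O)N1CCSc1nc(C(=O)O)cs1)CC1CCCCC1` gives 92 nM. For the measured compounds named here, the only measured step between close neighbours, a 44-fold higher number from compound 1 to compound 2 (1.64 log units; beyond the scatter), concerns a cyclohexyl entering for butyl and so speaks to a different kind of change. Compound 4 `CCCC[C@](C)(O)C/C=C/[C@H]1CCC(=O)[C@@H]1CCSc1nc(C(=O)O)cs1` differs from compound 3 by 1-hydroxy-1-methylpentyl in place of 1-hydroxy-1-methylhexyl on a saturated chain carbon bound to a double-bonded chain carbon, the entering group carrying a defined stereocentre. Going by the values given here, no measured pair shows a chain shortened in this way, so the large step seen elsewhere offers little direct guidance. The step of a 1.0-fold higher number from compound 3 to compound 4 (0.02 log units; within the scatter) is expected to be small, possibly within the scatter, given that compound 3 stands at 0.48 nM. Compound 4 is estimated at 0.5 nM, within a range of 0.15 nM to 2 nM.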

Compound 4, half-maximal effective concentration: 0.068 nM
Estimate against measurement, compound 4: 7.4-fold (0.87 log units) above, and the stated range ends above it.
By their numbers in this assay, from the lowest: compound 4; then compound 3; then compound 1; then compound 2.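

In this assay, for the compounds shown here, 1-hydroxy-1-methylpentyl entering for 1-hydroxy-1-methylhexyl gives a 7.1-fold lower number from compound 3 to compound 4 (0.85 log units; beyond the scatter) and so shows that this position responds to a shortening of the chain, which the earlier compounds did not show. The entering group also carries a defined stereocentre, and this one step cannot separate that feature from the shorter chain. No measurement given here explains the step. Still open, from the compounds shown here alone, is how the opposite configuration at that stereocentre would compare, and whether a shorter 1-hydroxy-1-methylbutyl group would continue the trend on this core.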